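Metabolic stability notes: methyl on the five-membered ring

The source may report more compounds than this note shows. Statements on the series, on what has been measured and on what is new or still open speak of the compounds shown alone.

Measured compounds:
compound 1 `Cc1cc(-c2ccccc2)n(/C(N)=N/S(=O)(=O)c2cc(C)c(Cl)cc2SCc2cccc3ccccc23)n1` gives 0.256 h in an ADME assay on microsomes from liver (Homo sapiens) for metabolic stability, read by LC-MS, using NADPH, tested at 5 uM; a higher number here means that the compound lasts longer, a lower number that the compound disappears faster
compound 2 `Cc1cc(-c2ccccc2)n(/C(N)=N/S(=O)(=O)c2cc(C)c(Cl)cc2SCc2cccc(C(F)(F)F)c2)n1` gives 0.169 h in this assay
compound 3 `Cc1cc(S(=O)(=O)/N=C(\N)n2nccc2-c2ccccc2)c(SCc2ccccc2)cc1Cl` gives 0.0772 h in this assay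

Compound 3 gives the lowest number of the three in this assay; both compound 2 and compound 1 stand higher, each by more than the usual scatter. Compound 4 `Cc1cc(-c2ccccc2)n(/C(N)=N/S(=O)(=O)c2cc(C)c(Cl)cc2SCc2ccccc2)n1` is compound 3 with one change: methyl in place of hydrogen on an aromatic carbon. For the measured compounds named here, no measured step covers this same change. Going by the values given here, the only step measured so far, a 1.5-fold lower number from compound 1 to compound 2 (0.18 log units; within the scatter), concerns the group on the sulfur-bound chain carbon and stays within the scatter. Compound 1 and compound 2 both carry the methyl that enters in compound 4, and both give higher numbers than compound 3, but they also differ from compound 3 in the sulfur-bound group, so the contribution of the methyl alone cannot be separated. A moderate rise is therefore expected, with wide uncertainty. The estimate for compound 4 is an expected step of a 1.8-fold higher number from compound 3 to compound 4 (0.26 log units; within the scatter), giving an expected value of 0.14 h, with a range from 0.07 h to 0.28 h.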

Compound 4, half-life: 0.0938 h
The estimate for compound 4 lay 1.5-fold (0.17 log units) above the measured number; measured number inside the range.
By their numbers in this assay, from the lowest: compounds 3, 4, 2 and 1 (each within the scatter of the next, the first and the last beyond it).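

In this assay, the methyl on the five-membered ring can now be read alone: a 1.2-fold higher number from compound 3 to compound 4 (0.08 log units; within the scatter). This holds for the pair with phenyl on the sulfur-bound chain carbon and shows no change beyond the scatter from this single added carbon. For the compounds shown here, with the methyl kept, hydrogen in place of trifluoromethyl gives a 1.8-fold lower number from compound 2 to compound 4 (0.26 log units; within the scatter), while phenyl in place of naphthalen-1-yl gives a 2.7-fold lower number from compound 1 to compound 4 (0.44 log units; beyond the scatter), the only one of these new steps beyond the scatter; no supporting measurement accompanies these numbers.

As far as these compounds go, whether the methyl reads the same with naphthalen-1-yl or 3-(trifluoromethyl)phenyl on the chain carbon remains open. Also open, from the compounds shown here alone, is how an amine or a carboxylic acid on this ring carbon would read in this assay.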